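From a chlorophenyl arm to a bare amino group

The compounds below may be only part of what the source reports. "The series", "measured", "known", "first", "only" and "open" are said of these compounds alone.

Of the compounds shown here, three built on a shared core have been tested in an assay on MCF7 cells for inhibition of Serine-protein kinase ATM (Homo sapiens), read by immunofluorescence, with a stated time of 1 h; a higher number here means a weaker inhibitor, a lower number a stronger inhibitor. Compound 1 `COc1ccc(-c2nc(N)n(-c3ncnc4ccccc34)n2)cc1` sits at the limit of the assay, giving > 40000 nM. Compound 2 `COc1cc2ncnc(-n3nc(-c4ccccc4)nc3N)c2cc1OC` gives a measured number, 2000 nM. Compound 3 `COc1cc2ncnc(-n3nc(-c4ccc(Cl)cc4)nc3N)c2cc1OC` again sits at the limit, with > 40000 nM. Within the data shown here, the only measured step among them, an at least 20-fold higher number from compound 2 to compound 3 (1.30 log units; beyond the scatter), runs from a number to a limit, and the limit of > 40000 nM in this assay, at which 2 of the 3 values shown sit, means that two of the three values tell no more than that the compounds are weak.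

Compound 4 `COc1cc2ncnc(-n3nc(N)nc3N)c2cc1OC` is obtained from compound 3 by a change at the same place where the earlier step acted: amino in place of 4-chlorophenyl on an aromatic carbon. Among the measured compounds shown here, no measured step covers an exchange of this kind; the step from compound 2 to compound 3 only shows that adding a chloro group to the phenyl ring weakened binding, and the limit gives no direction for removing the ring altogether. The expectation therefore leans on the weak standing of compound 3 in this assay and allows a wide spread. Compound 4 is expected to give about 30000 nM, within a range of 3000 nM to 40000 nM, which would amount to an estimated step of an at least 1.3-fold lower number from compound 3 to compound 4 (0.12 log units; that floor lies within the scatter).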

Compound 4, half-maximal inhibitory concentration: > 40000 nM
Compound 4: no number, only a limit (the forecaster's own chance of this, stated with the estimate: 60%); middle value at least 1.3-fold (0.12 log units) from the limit.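

In this assay, removing the phenyl ring from this aromatic carbon of the five-membered ring and leaving an amino group gives an at least 20-fold higher number from compound 2 to compound 4 (1.30 log units; beyond the scatter) and so takes the compound to the weak end of the assay. Adding a chloro group to the phenyl ring had already done the same, so both changes tried at this position from compound 2 lose binding, and on this shared core only the phenyl group of compound 2 gives a measured number. Compound 4 gives > 40000 nM, which is a limit of the assay, so the step from compound 3 cannot be read and neither of these two compounds can be ranked above the other, with most of the set now resting on the same ceiling: the limit of > 40000 nM in this assay, at which 3 of the 4 values shown sit.

On these data alone, whether a methyl group, a benzyl group or a pyridine ring on this carbon would keep or improve binding stays open. As far as these compounds go, it is also open whether a fluoro or methoxy group on the phenyl ring would be tolerated, since compound 2 with 2000 nM is the only reference point on this core that is a true number.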